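The source may hold more compounds than are shown below. What is called first, only, known or untested is meant among the compounds shown, and "the series" means these compounds.

Compounds measured in a functional assay on thoracic aorta (Rattus norvegicus) for inhibition; a higher number here means that more compound is needed for the effect, a lower number that less compound is needed:
compound 1 `CC1(C)CC(NC(=S)Nc2ccc(C#N)cc2)c2cc(NS(C)(=O)=O)ccc2O1` — 11600 nM
compound 2 `CCS(=O)(=O)Nc1ccc2c(c1)C(NC(=S)Nc1ccc(C#N)cc1)CC(C)(C)O2` — 12000 nM

Compound 2 and compound 1 give numbers within the scatter of each other, the step of a 1.0-fold higher number from compound 1 to compound 2 (0.01 log units; within the scatter). Compound 3 `CCS(=O)(=O)Nc1ccc2c(c1)C(NC(=S)Nc1ccc(Cl)cc1)CC(C)(C)O2` differs from compound 2 only by chloro in place of cyano on an aromatic carbon. For the measured compounds named here, no measured step touches this position; the one measured step concerns the sulfonyl side and gives no guide here. With nothing in the pair pointing either way, compound 3 is expected to sit close to compound 2, the expected step being no change at the digits printed from compound 2 to compound 3 (within the scatter). The estimate for compound 3 in this assay is 12000 nM, with a range from 4000 nM to 36000 nM.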

Compound 3, half-maximal effective concentration: 5100 nM
For compound 3 the middle estimate is 2.4-fold (0.37 log units) above the measured one, within the range that was stated.
By their numbers in this assay, from the lowest: compound 3; then compounds 1 and 2 (each within the scatter of the next).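

In this assay, the substituent on the aromatic ring of the (4-cyanophenyl)amino group affects the read-out: chloro in place of cyano gives a 2.4-fold lower number from compound 2 to compound 3 (0.37 log units; beyond the scatter), a modest step. For the compounds shown here, the sulfonyl-side change gave a smaller step, a 1.0-fold higher number from compound 1 to compound 2 (0.01 log units; within the scatter), so this is the first change to move the number beyond the scatter. No measurement of any property of these compounds bears on this step.

On these data alone, with a single replacement at this position, it remains open whether the lower number is specific to chloro. Hydrogen, fluoro, methoxy or trifluoromethyl at the same aromatic carbon would show how far the trend extends.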